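Ethoxy for nitro on the shared core

The source may report more compounds than this note shows. Statements on the series, on what has been measured and on what is new or still open speak of the compounds shown alone.

Of the compounds shown here, two carry numbers so far. Compound 1 `N#Cc1cccnc1N1CCN(Cc2nc3ccccc3[nH]2)CC1` in an assay on HEK293 cells with D(4) dopamine receptor (Homo sapiens) as the target, read by FLIPR (a lower number here means that less compound is needed, a higher number that more compound is needed for the effect), gives 13.9 nM. Compound 2 `O=[N+]([O-])c1ccccc1N1CCN(Cc2nc3ccccc3[nH]2)CC1` in this assay gives 3.9 nM, the lowest of the two numbers shown; the gap to compound 1 lies beyond the usual scatter, so compound 2 is the one of the two that needs less material for the half-maximal effect.

Compound 3 `CCOc1ccccc1N1CCN(Cc2nc3ccccc3[nH]2)CC1` has not been measured. It differs from compound 2 by ethoxy in place of nitro on an aromatic carbon, in words ethoxy in place of nitro on an aromatic carbon, ortho to a large group, with the rest of the structure unchanged. Among the measured compounds shown here, no measured pair carries this exchange, so no measured step guides it. A step of modest size in this assay is expected, more likely toward a higher number than toward a lower one, though an outcome within the scatter is also plausible. For compound 3 the estimate in this assay is 8 nM, with a range from 2 nM to 30 nM. The expected step is a 2.1-fold higher number from compound 2 to compound 3 (0.31 log units; beyond the scatter).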

Compound 3, half-maximal effective concentration: 25 nM
Estimate against measurement, compound 3: 3.1-fold (0.49 log units) below; measured number inside the range.
By their numbers in this assay, from the lowest: compound 2; then compounds 1 and 3 (each within the scatter of the next).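

In this assay, among the compounds shown here, the exchange of nitro for ethoxy on an aromatic carbon, ortho to a large group, gives a 6.4-fold higher number from compound 2 to compound 3 (0.81 log units; beyond the scatter), and this is the first change confined to a single place. The position is therefore not indifferent to what it carries: both groups count 3 heavy atoms and neither brings a ring or a net charge, yet the numbers differ beyond the scatter. Nothing measured here accounts for the size or direction of this step.

With a single pair at this position, the compounds shown do not separate what the loss of nitro contributes from what the arrival of ethoxy contributes, and they give no trend across substituents. Methoxy, an amine, a longer alkoxy chain or plain hydrogen on the same aromatic carbon, with the rest of the structure unchanged, would show whether the step belongs to ethoxy in particular or extends to other groups at this place.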